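This account rests on a few compounds, and the source may have more. Where it says the series, first, only, none or still open, it means among the compounds named here.

Measured so far in a functional assay on DU-145 cells (Homo sapiens) for inhibition, read by trypan blue exclusion, with a stated time of 96 h; on this read-out higher numbers stand for weaker inhibition of growth and lower numbers for stronger inhibition of growth:
- compound 1 `COc1cc(/C=C(/Sc2ccc(Br)cc2)C(=O)c2ccc(Br)cc2)ccc1F`: 10000 nM
- compound 2 `O=C(/C(=C\c1ccc(Br)c(O)c1)Sc1ccc(Br)cc1)c1ccc(Br)cc1`: 1000 nM
- compound 3 `O=C(/C(=C\c1ccc(OC(F)(F)F)cc1)S(=O)(=O)c1ccc(Br)cc1)c1ccc(Br)cc1`: 25000 nM

Compound 2, at 1000 nM, has the lowest number of the three. Compound 4 `O=C(/C(=C\c1ccc(I)cc1)Sc1ccc(Br)cc1)c1ccc(Br)cc1` is the next to be read against it. The change is 4-iodophenyl in place of 4-bromo-3-hydroxyphenyl on a double-bonded chain carbon bound to a double-bonded chain carbon, with 4-iodophenyl in place of 4-bromo-3-hydroxyphenyl on a double-bonded chain carbon bound to a double-bonded chain carbon.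

Within the data shown here, only one measured step involves this place: a 10-fold lower number from compound 1 to compound 2 (1.00 log units; beyond the scatter), where 4-bromo-3-hydroxyphenyl replaced 4-fluoro-3-methoxyphenyl. Compound 3 differs from the others in more than one place, so it offers no clean comparison. The step changed both substituents at once, and the data cannot separate their contributions. The 4-iodophenyl group has no hydroxy group, and neither does the ring of compound 1 at 10000 nM. A rise in the number is therefore expected, though probably not all the way back, as a 10-fold lower number from compound 1 to compound 2 (1.00 log units; beyond the scatter) gain may not rest on the hydroxy group alone. The expected change, which is uncertain with one step to go on, is a 3.0-fold higher number from compound 2 to compound 4 (0.48 log units; beyond the scatter). The estimate for compound 4 is 3000 nM, with an expected range of 800 nM to 12000 nM.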

Compound 4, concentration for 50% growth inhibition: 1000 nM
For compound 4 the middle estimate is 3.0-fold (0.48 log units) above the measured one; the range from low to high includes it.
By their numbers in this assay, from the lowest: compounds 2 and 4 (each within the scatter of the next); then compound 1; then compound 3.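

In this assay, the hydroxy group of 4-bromo-3-hydroxyphenyl is not needed to hold the activity at this place: 4-iodophenyl, with 0 hydrogen-bond donors and 0 hydrogen-bond acceptors, gives no change at the digits printed from compound 2 to compound 4 (within the scatter). Compound 1 can now be read against two different rings, and a 10-fold lower number from compound 1 to compound 4 (1.00 log units; beyond the scatter) matches a 10-fold lower number from compound 1 to compound 2 (1.00 log units; beyond the scatter), so the earlier gain cannot be tied to the hydroxy group, and a ring on this double-bonded chain carbon reaches the same level with or without it. Nothing on hand accounts for 4-iodophenyl and 4-bromo-3-hydroxyphenyl reading alike, or for 4-fluoro-3-methoxyphenyl reading higher than both.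

Still open, from the compounds shown here alone, is what the bromine and the hydroxy group of 4-bromo-3-hydroxyphenyl each contribute when taken one at a time, and whether the iodine of 4-iodophenyl matters at all compared with a ring carrying a methyl group, an amine or a carboxylic acid in its place. The sulfur link of compound 3 also remains unresolved, since that compound differs from the others in more than one place and its value cannot be assigned to either change.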